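Acyl variation on the piperazine of a chlorophenyl-propanoyl series

This account rests on a few compounds, and the source may have more. Where it says the series, first, only, none or still open, it means among the compounds named here.

Measured so far in a functional assay with Melanocortin receptor 4 (Homo sapiens) as the target, read by cAMP accumulation; on this read-out higher numbers stand for an effect only at larger amounts of compound and lower numbers for an effect already at smaller amounts:
compound 1 `CS(=O)(=O)N(CC1CC1)c1ccccc1N1CCN(C(=O)[C@H](CC(=O)N2CCNCC2)Cc2ccc(Cl)cc2)CC1` gives 2000 nM
compound 2 `CS(=O)(=O)N(CC1CC1)c1ccccc1N1CCN(C(=O)[C@H](CC(=O)N2CCN(C(=O)c3ccccc3)CC2)Cc2ccc(Cl)cc2)CC1` gives 83 nM

Compound 2 stands at the lowest of the two numbers; its nearest neighbour is compound 1, and the step of a 24-fold lower number from compound 1 to compound 2 (1.38 log units; beyond the scatter) lies beyond the scatter. That single step, benzoyl in place of hydrogen on the ring amine nitrogen, is the only one that bears on the present question.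

Compound 3 `CC(C)(C)CC(=O)N1CCN(C(=O)C[C@H](Cc2ccc(Cl)cc2)C(=O)N2CCN(c3ccccc3N(CC3CC3)S(C)(=O)=O)CC2)CC1` keeps the acyl group on that nitrogen but alters it: neopentyl in place of phenyl on a carbonyl carbon. No measured pair in the series separates an aromatic from an aliphatic acyl group at this position, so the direction of the step cannot be read from the numbers shown. What is known is that an acyl group there is worth a large gain, so compound 3 is expected to stay closer to compound 2 than to compound 1. With the neopentyl group carrying no ring, a small loss relative to compound 2 is estimated, a 1.8-fold higher number from compound 2 to compound 3 (0.26 log units; within the scatter), within or just beyond the scatter. Compound 3 is therefore estimated at 150 nM, with a range from 40 nM to 600 nM.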

Compound 3, half-maximal effective concentration: 74 nM
Estimate against measurement, compound 3: 2.0-fold (0.31 log units) above; low and high end bracket the measured number.
By their numbers in this assay, from the lowest: compounds 3 and 2 (each within the scatter of the next); then compound 1.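

In this assay, the step of a 1.1-fold lower number from compound 2 to compound 3 (0.05 log units; within the scatter) shows that the benzoyl ring is not required at this position: neopentyl, with no ring, reads the same as phenyl on this carbonyl carbon. The large gain from acylating the ring amine nitrogen, so far seen only with benzoyl, also appears with an aliphatic acyl group, as a 27-fold lower number from compound 1 to compound 3 (1.43 log units; beyond the scatter) shows, so it is not confined to the aromatic case among the compounds shown. No measurement is available that could explain this equivalence or the gain.

Both acyl groups shown carry only carbon beyond the carbonyl, so it remains open whether a shorter acetyl group, or an acyl chain ending in an amine or a carboxylic acid, would keep the gain. Going by these compounds, it also remains open whether the carbonyl itself matters, which a benzyl or methanesulfonyl group on the same nitrogen would test.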